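A Methoxy Group Added to a Pyrazoline-Bearing Thiazolone

The source may report more compounds than this note shows. Statements on the series, on what has been measured and on what is new or still open speak of the compounds shown alone.

Of the compounds shown here, three have been measured in a functional assay on cells (Cancer cell lines, Homo sapiens) for cytotoxicity, read by sulforhodamine B assay, with a stated time of 48 h; a lower number here means a stronger inhibitor of growth, a higher number a weaker inhibitor of growth. Compound 1 `COc1ccc(C2CC(c3ccccc3)=NN2C2=NC(=O)/C(=C3\C(=O)Nc4ccc(Br)cc43)S2)cc1` gives 200 nM in this assay. Compound 2 `COc1ccc(C2=NN(C3=NC(=O)/C(=C4\C(=O)Nc5ccc(Br)cc54)S3)C(c3ccc(OC)cc3)C2)cc1` gives 200 nM in this assay. The two differ by one change, (methoxy in place of hydrogen on an aromatic carbon), and the step it made reads no change at the digits printed from compound 1 to compound 2 (within the scatter).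

Compound 3 `O=C1N=C(N2N=C(c3ccccc3)CC2c2ccc(Cl)cc2)S/C1=C1/C(=O)Nc2ccccc21` gives 230 nM in this assay. Compound 3 and compound 1 are built on cores that are not the same; the difference between the two cores is not broken down here. Compound 3 has the highest of the three numbers, but its gaps to compound 1 and to compound 2 are both within the scatter, so nothing in this set can be called stronger or weaker than another.

Compound 4 `COc1ccc(C2=NN(C3=NC(=O)/C(=C4\C(=O)Nc5ccccc54)S3)C(c3ccc(Cl)cc3)C2)cc1` has not yet been measured. For the measured compounds named here, it differs from compound 3 by methoxy in place of hydrogen on an aromatic carbon, which is the same change as the one from compound 1 to compound 2, made at the same kind of place. Because that earlier step gave no change at the digits printed from compound 1 to compound 2 (within the scatter), the step from compound 3 to compound 4 in this assay is expected to be small as well, roughly no change at the digits printed from compound 3 to compound 4 (within the scatter). This expectation rests on a single earlier pair, so it carries the uncertainty of one example. Compound 4 is therefore estimated at 230 nM in this assay, with a likely range from 115 nM to 460 nM.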

Compound 4, concentration for 50% growth inhibition: 92400 nM
For compound 4 the middle estimate is 400-fold (2.60 log units) below the measured one; the whole stated range lies below it.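

In this assay, the change from phenyl to 4-methoxyphenyl gives a 400-fold higher number from compound 3 to compound 4 (2.60 log units; beyond the scatter), which means a far weaker inhibitor of growth, whereas the same change on the core of compound 1 gave no change at the digits printed from compound 1 to compound 2 (within the scatter). Set side by side, the two steps show that this change does not carry over from one core to the other in this series: the same change on two cores in this assay, no change at the digits printed (within the scatter) from compound 1 to compound 2 and a 400-fold higher number (2.60 log units; beyond the scatter) from compound 3 to compound 4, 400-fold (2.60 log units) apart, beyond the scatter of two such steps This rests on only two pairs of compounds, so it shows that the effect of adding the methoxy group depends on its surroundings, but it does not show why, and it does not show that the group is harmful on cores other than that of compound 3.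

The cores of compound 1 and compound 3 differ in more than one place, and the compounds shown leave open which of those differences decides whether the methoxy group is tolerated. Also open, on these data alone, is how another group in the same place, such as a hydroxyl group, an amine or a longer chain like ethoxy, would behave on the core of compound 3.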